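The source may report more compounds than this note shows. Statements on the series, on what has been measured and on what is new or still open speak of the compounds shown alone.

Three compounds built on one shared core were tested in a functional assay on U-937 cells (Homo sapiens) for cytotoxicity, read by CCK-8 assay, with a stated time of 72 h; on this read-out lower numbers stand for stronger inhibition and higher numbers for weaker inhibition. Compound 1 `COc1ccccc1/C=c1\c(=O)[nH]/c(=C/c2cccc(Cl)c2Cl)c(=O)n1C` gives 100 nM in this assay. Compound 2 `C=CCn1c(=O)/c(=C\c2ccc(Cl)c(Cl)c2)[nH]c(=O)/c1=C\c1ccccc1` gives "not active" (no number reported) in this assay. Compound 3 `C=CCn1c(=O)/c(=C\c2ccc(F)c(Br)c2)[nH]c(=O)/c1=C\c1ccccc1OC` also gives "not active" (no number reported) in this assay, so no single number stands for it, and compound 2 is the only other entry without a single number. Compound 4 `C=CCn1c(=O)/c(=C\c2ccc(C)cc2)[nH]c(=O)/c1=C\c1ccccc1OC` has not yet been measured. It differs from compound 3 in one place: 4-methylphenyl in place of 3-bromo-4-fluorophenyl on a double-bonded chain carbon bound to an aromatic carbon. Within the data shown here, compound 4 shares far more of its structure with compound 3 and compound 2, neither of which gave a number, than with compound 1, the one compound that did. Among the measured compounds shown here, no measured pair differing in a single place exists here, and no shift beyond the scatter in this assay can be foreseen; the most likely outcome is that compound 4 again falls outside the range the assay reports as a number. Compound 4 is therefore expected to give about 30000 nM in this assay, within roughly 5000 nM to 100000 nM.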

Compound 4, half-maximal inhibitory concentration: "not active" (no number reported)
Compound 4 has no reported number here, and the estimate cannot be compared.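

Compound 3 and compound 4 both give no number in this assay, so no step can be read between them. No measured evidence on hand bears on this result. The compounds shown leave open how a change in one place would shift a measured number on the shared core.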